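From Fluoro to Methoxy on a Weak Aryl Analogue

This account rests on a few compounds, and the source may have more. Where it says the series, first, only, none or still open, it means among the compounds named here.

In a functional assay on HCT-116 cells (Homo sapiens) for antiproliferative activity, with a stated time of 72 h (a higher number here means a weaker inhibitor, a lower number a stronger inhibitor), compound 1 `CCCC#Cc1cc([C@@H]2O[C@H](CO)[C@@H](O)[C@H]2O)n2ncnc(N)c12` gives 200 nM, compound 2 `Nc1ncnn2c([C@@H]3O[C@H](CO)[C@@H](O)[C@H]3O)cc(C#Cc3ccccc3)c12` gives 46900 nM and compound 3 `Nc1ncnn2c([C@@H]3O[C@H](CO)[C@@H](O)[C@H]3O)cc(-c3ccc(F)cc3)c12` gives 42500 nM. Compound 3 thus stands within the scatter of compound 2 and well above compound 1. Compound 4 `COc1ccc(-c2cc([C@@H]3O[C@H](CO)[C@@H](O)[C@H]3O)n3ncnc(N)c23)cc1` has methoxy in place of fluoro on an aromatic carbon, para to a large group: methoxy in place of fluoro on an aromatic carbon. Among the compounds with values here, no measured step tests this exchange directly. The large steps, a 230-fold higher number from compound 1 to compound 2 (2.37 log units; beyond the scatter) and a 210-fold higher number from compound 1 to compound 3 (2.33 log units; beyond the scatter), both remove the pent-1-yn-1-yl group, which compound 4 also lacks. The closest guide is a 1.1-fold lower number from compound 2 to compound 3 (0.04 log units; within the scatter), so only a small change is expected, namely a 1.1-fold lower number from compound 3 to compound 4 (0.03 log units; within the scatter). For compound 4 the expected value is 40000 nM, within an estimated range of 15000 nM to 100000 nM.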

Compound 4, half-maximal inhibitory concentration: 47100 nM
For compound 4 the middle estimate is 1.2-fold (0.07 log units) below the measured one, and the stated range covers the measured number.
By their numbers in this assay, from the lowest: compound 1; then compounds 3, 2 and 4 (each within the scatter of the next).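

In this assay, methoxy and fluoro on this aromatic carbon, para to a large group, read alike (a 1.1-fold higher number from compound 3 to compound 4 (0.04 log units; within the scatter)), so the added oxygen and carbon of the methoxy group shift nothing beyond the scatter. The 4-methoxyphenyl group also reads alike with 2-phenylethynyl (a 1.0-fold higher number from compound 2 to compound 4 (0.00 log units; within the scatter)), while compound 1 remains far apart (a 240-fold higher number from compound 1 to compound 4 (2.37 log units; beyond the scatter)). Nothing available bears on the reason for this result. Going by these compounds, whether an amine or a carboxylic acid on this aromatic carbon would read differently remains open, as does the effect of a longer chain in place of pent-1-yn-1-yl.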